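The source may report more compounds than this note shows. Statements on the series, on what has been measured and on what is new or still open speak of the compounds shown alone.

Compound 1 `Cc1nc([C@@H](NC(=O)c2ccc(-c3ccc(Cl)c(F)c3)[nH]2)[C@@H]2CCCCN2)sc1CCO` and compound 2 `Cc1nc([C@@H](NC(=O)c2ccc(-c3ccc(Cl)cc3)[nH]2)[C@@H]2CCCCN2)sc1CCO` share a core and differ only in one place: hydrogen in place of fluoro on an aromatic carbon. In a toxicity assay on TZM cells (Homo sapiens) for cytotoxicity, read by XTT assay, with a stated time of 3 days (a higher number here means that more compound is tolerated, a lower number that less compound is tolerated), compound 1 gives 16100 nM, and in this assay compound 2 gives 17300 nM, so the change made a 1.1-fold higher number from compound 1 to compound 2 (0.03 log units; within the scatter). Compound 3 `Cc1nc([C@H](NC(=O)c2ccc(-c3ccc(Cl)c(F)c3)[nH]2)[C@@H]2CCCCN2)sc1CCCO` carries a different core; the difference between the two cores is not broken down here. In this assay compound 3 gives 8200 nM, which is the lowest of the three numbers; its gap to compound 1 lies within the usual scatter, while its gap to compound 2 lies beyond it.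

Compound 4 `Cc1nc([C@H](NC(=O)c2ccc(-c3ccc(Cl)cc3)[nH]2)[C@@H]2CCCCN2)sc1CCCO` is the partner of compound 3 in the same way that compound 2 is the partner of compound 1. How compound 4 differs from compound 3 is hydrogen in place of fluoro on an aromatic carbon. The place around the change is the same, word for word, as in the pair compound 1 to compound 2, so this is the same change made on the other core. Since that change gave a 1.1-fold higher number from compound 1 to compound 2 (0.03 log units; within the scatter), a step within the scatter, the expectation is that the step from compound 3 to compound 4 will likewise be small, estimated as a 1.1-fold higher number from compound 3 to compound 4 (0.04 log units; within the scatter). On that basis compound 4 is expected to give about 9000 nM in this assay, with the estimate likely falling between 4500 nM and 18000 nM.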

Compound 4, half-maximal cytotoxic concentration: 13700 nM
For compound 4 the middle estimate is 1.5-fold (0.18 log units) below the measured one, within the range that was stated.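

On the core of compound 3, replacing the 4-chloro-3-fluorophenyl group with 4-chlorophenyl gave a 1.7-fold higher number from compound 3 to compound 4 (0.22 log units; within the scatter) in this assay, so the step stays within the usual scatter, as it does on the core of compound 1. Set side by side, the two steps do not differ: the same change on two cores in this assay, a 1.1-fold higher number (0.03 log units; within the scatter) from compound 1 to compound 2 and a 1.7-fold higher number (0.22 log units; within the scatter) from compound 3 to compound 4, 1.6-fold (0.19 log units) apart, within the scatter of two such steps. This shows that, for these two pairs, the change carried from one core to the other without a step that can be told from the scatter in this assay, but it does not show that the same would hold on any further core, nor does it tell which of the differences between the two cores, if any, matters to the numbers.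

The compounds shown leave open whether a nitrile or a methyl group in the place of the fluoro would also stay within the scatter in this assay, and whether the same would hold with trifluoromethyl in the place of the chloro group. They also leave open how this change would read on a core whose side chain ends in a carboxylic acid or an amine rather than an alcohol.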